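The compounds below may be only part of what the source reports. "The series", "measured", "known", "first", "only" and "open" are said of these compounds alone.

Two compounds have been measured so far:
compound 1, `Cc1cc(-c2nc(CN3CCCC3)nn2C)ccc1C(F)(F)F`, which in an assay on membranes from Jurkat cells for displacement of a labelled ligand from Sigma non-opioid intracellular receptor 1 (Homo sapiens), read by scintillation counting, with a stated time of 2 h (a higher number here means a weaker inhibitor, a lower number a stronger inhibitor), gives 21 nM;
compound 2, `CCn1nc(CN2CCCC2)nc1-c1ccc(C(C)(C)C)cc1`, which in this assay gives 4.8 nM.

Compound 2 has the lower of the two numbers, so it is the stronger inhibitor of the pair; the number for compound 1 is higher by a gap that lies beyond the usual scatter. The two compounds differ in more than one place, so no single structural change can be read off from their values.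

Compound 3, `Cn1nc(CN2CCCC2)nc1-c1ccc(C(C)(C)C)cc1`, has not yet been measured. It differs from compound 2 in just one place:

hydrogen in place of methyl on a saturated chain carbon bound to an aromatic nitrogen

Seen from one bond further out, this is an ethyl becoming a methyl. Among the compounds with values here, a change this small usually moves the number in this assay only a little, and the data give no step of this kind to lean on. The expectation is a step of a 1.5-fold higher number from compound 2 to compound 3 (0.16 log units; within the scatter), a slightly higher number, within the scatter. For compound 3 the estimate is 7 nM, with a range from 2.5 nM to 20 nM.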

Compound 3, inhibition constant: 7.5 nM
Estimate against measurement, compound 3: 1.1-fold (0.03 log units) below, within the range that was stated.
By their numbers in this assay, from the lowest: compounds 2 and 3 (each within the scatter of the next); then compound 1.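

The change from ethyl to methyl gives a 1.6-fold higher number from compound 2 to compound 3 (0.19 log units; within the scatter) in this assay. Within the data shown here, this is the first comparison in the set in which only one place differs, and it shows that compound 2 and compound 3 cannot be told apart in this measurement, even though one carbon has gone from the chain at this position. No independent measurement bears on this result, so the data offer no explanation for how closely the two compounds agree.

On these data alone, only ethyl and methyl are compared here, so it remains open whether a longer chain such as propyl, a ring such as cyclopropyl, or a chain ending in an amine would also leave the number within the scatter at this position. The shown compounds also offer no step that changes only the tert-butyl group or only the trifluoromethyl group, so the separate contribution of each of these groups to the number remains unknown.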